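Permeability of the shared core with a varied piperazine

The compounds below may be only part of what the source reports. "The series", "measured", "known", "first", "only" and "open" are said of these compounds alone.

Compound 1 `C[C@@H]1CN(c2cccc3c2C[C@H](CN(C)[C@H]2CCCc4cccnc42)NC3)C[C@H](C)N1`: 39 nm/s
Compound 2 `CN(C[C@@H]1Cc2c(cccc2N2CCNCC2)CN1)[C@H]1CCCc2cccnc21`: 4 nm/s
Compound 3 `Cc1cnc2c(c1)CCC[C@@H]2N(C)C[C@H]1Cc2c(cccc2N2CCNCC2)CN1`: 9 nm/s

Of the compounds shown here, three built on the shared core have been measured in an ADME assay for permeability, using PAMPA, at pH 7.4; a higher number here means that the compound crosses the layer faster, a lower number that the compound crosses the layer more slowly. Compound 1 gives 39 nm/s and stands highest of the three. The nearest to it is compound 3, which gives 9 nm/s, a gap that lies beyond the scatter, and the furthest is compound 2, which gives 4 nm/s, also beyond the scatter. None of these three pairs differs in only one place, so no single step can be read from them.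

Compound 4 `CCN1CCN(c2cccc3c2C[C@H](CN(C)[C@H]2CCCc4cccnc42)NC3)CC1` has not yet been measured. It differs from compound 1 in one place: 4-ethylpiperazin-1-yl in place of 3,5-dimethylpiperazin-1-yl on an aromatic carbon. The two compounds have the same atoms, joined differently; the group that enters carries no hydrogen-bond donor, where the group that leaves carries one, and the two defined stereocentres of the leaving group are gone.

Going by the values given here, with no measured step of this kind available, the size of the change is uncertain. Given that compound 1 already gives 39 nm/s, compound 4 is expected to sit at a similar or somewhat higher level, a step of a 1.4-fold higher number from compound 1 to compound 4 (0.15 log units; within the scatter) that may not exceed the scatter. The estimate for compound 4 in this assay is 55 nm/s, in the range 20 nm/s to 150 nm/s.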

Compound 4, apparent permeability: 205 nm/s
Beside the measured number, compound 4's estimate is 3.7-fold (0.57 log units) below it; measured number above the stated range.
By their numbers in this assay, from the lowest: compound 2; then compound 3; then compound 1; then compound 4.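

Going by these compounds alone, on the shared core, this exchange at an aromatic carbon of the six-membered aromatic ring gives the first single step that can be read in this assay: a 5.3-fold higher number from compound 1 to compound 4 (0.72 log units; beyond the scatter), a step beyond the scatter. It shows that this position is sensitive to how the atoms of the piperazine substituent are joined, even though the heavy-atom count and ring type stay the same, and compound 4 now gives the highest number of the four at 205 nm/s. The two groups differ in that 3,5-dimethylpiperazin-1-yl has 1 hydrogen-bond donor and 2 defined stereocentres, whereas 4-ethylpiperazin-1-yl has 0 hydrogen-bond donors, but nothing available here ties the step to either of these differences.

The compounds shown leave open how the number would respond to other groups at this aromatic carbon, such as 4-methylpiperazin-1-yl, 4-propylpiperazin-1-yl or a morpholine ring. They also leave open whether the same exchange would give a step of similar size on a compound other than compound 1, since this single pair is the only one that carries it.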